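Series notes: one added group on the shared core

This account rests on a few compounds, and the source may have more. Where it says the series, first, only, none or still open, it means among the compounds named here.

In an ADME assay on HepG2 cells (Homo sapiens) for cytotoxicity, read by CellTiter-Glo, with a stated time of 72 h (on this read-out lower numbers stand for an effect already at smaller amounts and higher numbers for an effect only at larger amounts of compound), compound 1 `CC1=C2CC(C)(C)/C=C/C/C(C)=C\C3=C[C@H](C)C[C@]3(O2)C1=O` gives 26000 nM and compound 2 `CC1=C2CC(C)(C)/C=C/C(=O)/C(C)=C\C3=C[C@H](C)C[C@]3(O2)[C@]1(C)O` gives 26000 nM as its value. The two stand level at the digits shown, within the scatter, so compound 1 sits with its nearest neighbour and the series offers no measured spread in this assay to work from.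

Compound 3 `CC1=C2CC(C)(C)/C=C/[C@H](OC(=S)n3ccnc3)/C(C)=C\C3=C[C@H](C)C[C@]3(O2)C1=O` keeps the core of compound 1 and carries one change: a group of 8 heavy atoms (4 carbon, 2 nitrogen, 1 oxygen, 1 sulfur; one five-membered aromatic ring with 2 hetero atoms) in place of a hydrogen atom, on a saturated ring carbon on a saturated ring carbon, next to the ring atom that bears a methyl group. Within the data shown here, neither measured compound holds a group of this kind, and no step between measured compounds exists to scale the change. Among the measured compounds shown here, the only anchor is compound 1 at 26000 nM and the expectation therefore stays loose. A modest move toward lower numbers is expected, with a 2.2-fold lower number from compound 1 to compound 3 (0.34 log units; beyond the scatter) as the estimated step, close to the edge of the scatter. For compound 3 the estimated value is 12000 nM with an expected range of 3000 nM to 40000 nM in four of five repeats.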

Compound 3, half-maximal effective concentration: 26000 nM
For compound 3 the middle estimate is 2.2-fold (0.34 log units) below the measured one; measured number inside the range.
By their numbers in this assay, from the lowest: compounds 1, 2 and 3 (each within the scatter of the next).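

In this assay the series gains its first readable step: a group of 8 heavy atoms with one five-membered aromatic ring with 2 hetero atoms, in place of a hydrogen atom, gives no change at the digits printed from compound 1 to compound 3 (within the scatter). At this position, on a saturated ring carbon next to the ring atom that bears a methyl group, a group of this size with 4 hydrogen-bond acceptors and no net charge therefore leaves the read-out level with the core of compound 1, a statement that holds for this one group only. Nothing on hand accounts for this flat result.

Since this is the only group shown at this carbon, it remains open whether a smaller or differently built group, such as a hydroxyl, an amine or a carboxylic acid, would stay level with compound 1 or move the number beyond the scatter. With all three compounds level, the compounds shown also leave open whether any change on the shared core can separate compounds in this assay.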